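This account rests on a few compounds, and the source may have more. Where it says the series, first, only, none or still open, it means among the compounds named here.

Series notes, variation of the group that sits para to the shared core.

Compound 1 `COc1ccc(-c2cc(-c3ccc(S(=O)(=O)NC4CC4)cc3)cnc2N)cn1` gives 2.7 in a physicochemical assay for lipophilicity, at pH 7.4; on this read-out lower numbers stand for lower lipophilicity and higher numbers for higher lipophilicity. Compound 2 `COc1ccc(-c2cc(-c3ccc(C(F)(F)F)cc3)cnc2N)cn1` gives 4.2 in this assay, and compound 3 `COc1ccc(-c2cc(-c3ccc(-n4cncn4)cc3)cnc2N)cn1` gives 2.4. Compound 3 holds the lowest of the three numbers; its nearest neighbour is compound 1, and the step of a number 0.30 log units lower from compound 1 to compound 3 (within the scatter) stays within the scatter, so these two cannot be ordered. Its furthest neighbour is compound 2, and the step of a number 1.80 log units lower from compound 2 to compound 3 (beyond the scatter) is large, as is the step of a number 1.50 log units higher from compound 1 to compound 2 (beyond the scatter).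

Compound 4 `COc1ccc(-c2cc(-c3ccc(C(N)=O)cc3)cnc2N)cn1` is not yet measured. Its difference from compound 3 is carbamoyl in place of 1H-1,2,4-triazol-1-yl on an aromatic carbon. Two measured steps end at compound 3 and bear on the position in question: the exchange of cyclopropylsulfamoyl for 1H-1,2,4-triazol-1-yl left the number essentially unchanged, while the exchange of trifluoromethyl for 1H-1,2,4-triazol-1-yl lowered it strongly. Going by the values given here, no measured step involves carbamoyl, so the direction rests on the range the three groups span. Carbamoyl is expected to sit at or a little under the triazolyl number; the step of a number 0.50 log units lower from compound 3 to compound 4 (beyond the scatter) is the estimated shift. Compound 4 is expected to give about 1.9, with a range from 1.3 to 2.5.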

Compound 4, distribution coefficient: 1.7
Estimate against measurement, compound 4: 0.20 log units above; measured number inside the range.
By their numbers in this assay, from the lowest: compound 4; then compounds 3 and 1 (each within the scatter of the next); then compound 2.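

In this assay this position now separates groups below the level shared by cyclopropylsulfamoyl and 1H-1,2,4-triazol-1-yl: carbamoyl gives a number 0.70 log units lower from compound 3 to compound 4 (beyond the scatter) and also a number 1.00 log units lower from compound 1 to compound 4 (beyond the scatter) and so holds the lowest number of the four. The span at this position also widens, since measured against trifluoromethyl the change gives a number 2.50 log units lower from compound 2 to compound 4 (beyond the scatter) and the gap between the ends of the series is now the largest step seen. The exchange replaces a five-membered aromatic ring with a group that has no ring and fewer heavy atoms and brings in a hydrogen-bond donor, but nothing here separates these differences or gives a cause for the step.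

Still open, from the compounds shown here alone, is whether a methyl-substituted carboxamide, a nitrile, a carboxylic acid or a primary amine at this position would fall near carbamoyl, lie further down or return to the level of the triazolyl group. Going by these compounds, all these steps are read on the shared core with the group para to a large group, so it also remains open whether carbamoyl would bring a step of similar size on another core.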